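The source may report more compounds than this note shows. Statements on the series, on what has been measured and on what is new or still open speak of the compounds shown alone.

Compound 1, `Cc1cc(OCc2ccccn2)n2nc(C)c(-c3ccccc3)c2n1`, gives 25600 nM in a physicochemical assay for solubility, read by HPLC, using the shake flask method, measured as kinetic solubility, with a stated time of 2 h, at pH 7.4; a higher number here means a more soluble compound, a lower number a less soluble compound. Compound 2, `Cc1cc(NCc2ccccn2)n2ncc(-c3ccc(N(C)C)cc3)c2n1`, differs from compound 1 in more than one place, so the two values can only be set side by side. For compound 2 this assay reports only a limit, < 5000 nM, and not a number; it is the limit of < 5000 nM in this assay, at which 1 of the 2 values shown sits. Compound 3, `Cc1cc(NCc2ccccn2)n2ncc(C3=CCC(F)(F)CC3)c2n1`, has not yet been measured. It differs from compound 2 by 4,4-difluorocyclohex-1-en-1-yl in place of 4-(dimethylamino)phenyl on an aromatic carbon. Among the measured compounds shown here, since compound 2 is known only through a limit, no measured step frames this change, and the shift from compound 2 to compound 3 is expected to stay within the usual scatter, in either direction. The value expected for compound 3 in this assay is 4000 nM, with a range from 1000 nM to 16000 nM. That would mean an expected step that the limit leaves unreadable from compound 2 to compound 3. From the compounds shown here alone, whether this assay again reports only a limit for compound 3 remains open.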

Compound 3, solubility: 5000 nM
Compound 3: the middle estimate sits 1.3-fold (0.10 log units) below what was measured, within the range that was stated.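

In this assay, going from the 4-(dimethylamino)phenyl group to the 4,4-difluorocyclohex-1-en-1-yl group on the five-membered aromatic ring gives a readable number at this position, and the result is a number no lower from compound 2 to compound 3 (the limit leaves the size open). For compound 2, the entry < 5000 nM is a limit of the assay and not a number. From the compounds shown here alone, the change can therefore be read from one side only, and its size stays unknown: the limit of < 5000 nM in this assay, at which 1 of the 3 values shown sits.

The compounds shown leave open how much of this outcome belongs to the two fluorine atoms and how much to the non-aromatic ring, since a plain cyclohexenyl group does not appear among them. They also leave open how a morpholine or a carboxylic acid at this position would read in this assay.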